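A Methoxyphenyl Ether Replaces the Fluorophenyl Ether

The compounds below may be only part of what the source reports. "The series", "measured", "known", "first", "only" and "open" are said of these compounds alone.

Compound 1 `COc1cccc(CNCCCNc2ccnc3cc(Oc4ccc(F)cc4)ccc23)c1O` belongs to a small set of three measured compounds sharing one core. In an ADME assay for permeability, using PAMPA, with a stated time of 30 min, at pH 7.4 (a lower number here means that the compound crosses the layer more slowly, a higher number that the compound crosses the layer faster), compound 1 gives 317 10^-6 cm/s and stands level with compound 2 `Fc1ccc(Oc2ccc3c(NCCCNCc4ccco4)ccnc3c2)cc1` at the digits shown, which gives 317 10^-6 cm/s; together these are the highest of the three numbers, though the gap to compound 3 `COc1cccc(CNCCCNc2ccnc3cc(-c4cc(C(F)(F)F)cc(C(F)(F)F)c4)ccc23)c1O`, which gives 237 10^-6 cm/s, lies within the scatter.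

Compound 4 `COc1cccc(Oc2ccc3c(NCCCNCc4cccc(OC)c4O)ccnc3c2)c1` has not yet been measured. It differs from compound 1 in one place: 3-methoxyphenyl in place of 4-fluorophenyl on an oxygen on an aromatic ring. Cut one bond further out, the change reads 4-fluorophenoxy to 3-methoxyphenoxy.

For the measured compounds named here, only one step between measured compounds is available, no change at the digits printed from compound 1 to compound 2 (within the scatter), and it concerns the amine end of the chain rather than the aryl ether, so it bears on the present change only by showing that this assay tolerated one exchange at the periphery without movement. Compound 3 alters the same outer ring as compound 4 and its value sits within the scatter of compound 1. On these grounds no step beyond the scatter is expected for compound 4, so a 1.1-fold lower number from compound 1 to compound 4 (0.02 log units; within the scatter) is expected to be small. Compound 4 is estimated at 300 10^-6 cm/s, with a range from 190 10^-6 cm/s to 420 10^-6 cm/s.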

Compound 4, apparent permeability: 317 10^-6 cm/s
Estimate against measurement, compound 4: 1.1-fold (0.02 log units) below; low and high end bracket the measured number.
By their numbers in this assay, from the lowest: compounds 3, 1, 2 and 4 (each within the scatter of the next).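

The exchange of 4-fluorophenyl for 3-methoxyphenyl on an oxygen on an aromatic ring gives no change at the digits printed from compound 1 to compound 4 (within the scatter) in this assay and is the first step shown at this position, the earlier step having concerned the amine end of the chain. The group that enters has one more heavy atom and one more hydrogen-bond acceptor than the group that leaves, and it carries oxygen in place of fluorine, yet these differences come with no step beyond the scatter. Nothing given accounts for this result.

Since no step shown lies beyond the scatter, the compounds do not reveal what would move this read-out at this position. On these data alone, whether a carboxylic acid or an amine on the outer ring would leave the number within the scatter remains open.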